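The compounds below may be only part of what the source reports. "The series", "measured", "known", "first", "only" and "open" are said of these compounds alone.

Measured so far:
- Compound 1 `NC(=O)[C@@H](CCC(F)(F)F)N(C[C@H]1CCCCO1)S(=O)(=O)c1ccc(Cl)cc1` gives 13.4 10^-6 cm/s
- Compound 2 `NC(=O)[C@@H](CCC(F)(F)F)N(CC1CCOCC1)S(=O)(=O)c1ccc(Cl)cc1` gives 26.3 10^-6 cm/s

Going by the values given here, in an ADME assay on MDCKII-LE cells (Canis lupus familiaris) for permeability, read by transwell migration, in the apical to basolateral direction (a higher number here means that the compound crosses the layer faster, a lower number that the compound crosses the layer more slowly), compound 2 at 26.3 10^-6 cm/s lies within the usual scatter of compound 1, the only other compound measured, so the two cannot be ranked. The next compound, compound 3 `NC(=O)[C@@H](CCC(F)(F)F)N(C[C@H]1COCCO1)S(=O)(=O)c1ccc(Cl)cc1`, differs from compound 2 in one ring: 1,4-dioxan-2-yl in place of oxan-4-yl on a saturated chain carbon bound to a sulfonamide nitrogen. Put simply, 1,4-dioxan-2-yl stands in place of oxan-4-yl on a saturated chain carbon bound to a sulfonamide nitrogen.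

Among the compounds with values here, only one measured step bears on this: a 2.0-fold higher number from compound 1 to compound 2 (0.29 log units; within the scatter). That step exchanged one oxan ring for another, and it is a rough guide to how far a ring exchange on this core can move the number. Within the data shown here, no measured step goes from an oxan ring to a 1,4-dioxan-2-yl ring, so the direction is a judgement from the structural change alone. A modest drop is expected, and it may not clear the scatter. The expected change is a 1.8-fold lower number from compound 2 to compound 3 (0.24 log units; within the scatter). For compound 3 the estimated value is 15 10^-6 cm/s, with an expected range of 7 10^-6 cm/s to 30 10^-6 cm/s.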

Compound 3, apparent permeability: 20.6 10^-6 cm/s
Estimate against measurement, compound 3: 1.4-fold (0.14 log units) below; the measured number falls inside the stated range.
By their numbers in this assay, from the lowest: compounds 1, 3 and 2 (each within the scatter of the next).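

In this assay, 1,4-dioxan-2-yl in place of oxan-4-yl adds a second ring oxygen and a second hydrogen-bond acceptor on a saturated chain carbon bound to a sulfonamide nitrogen, yet the result is only a small step (a 1.3-fold lower number from compound 2 to compound 3 (0.11 log units; within the scatter)), so this exchange cannot be told apart from repeat-measurement noise. Compared with the oxan-2-yl ring, the same group gives a similar reading (a 1.5-fold higher number from compound 1 to compound 3 (0.19 log units; within the scatter)), which means that the three six-membered rings seen at this place, each with no net charge, cannot be separated in this measurement, whether they carry one ring oxygen or two. No independent measurement is available to explain why these numbers fall as they do.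

From the compounds shown here alone, all three compounds carry a non-aromatic oxygen ring here, so it remains open whether an amine or a carboxylic acid at this place, or a longer chain leading to the ring, would produce a step beyond the scatter. Going by these compounds, the mirror-image form of the 1,4-dioxan-2-yl group also remains open, since compound 3 shows only one arrangement at its defined stereocentre.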